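Trimming the Side Chain of Compound 2

The source may hold more compounds than are shown below. What is called first, only, known or untested is meant among the compounds shown, and "the series" means these compounds.

Compound 1 `CN(/N=N/c1ccccc1)c1ccccc1` gives 55000 nM
Compound 2 `CN(C)CCCN(/N=N/c1cccc([N+](=O)[O-])c1)c1ccccc1` gives 14000 nM

In an ADME assay on MT4 cells (Homo sapiens) for cytotoxicity, read by MTT assay, with a stated time of 96 h (a higher number here means that more compound is tolerated, a lower number that less compound is tolerated), compound 2 holds the lower of the two numbers at 14000 nM and compound 1 lies higher at 55000 nM by more than the usual scatter. Compound 3 `CN(/N=N/c1cccc([N+](=O)[O-])c1)c1ccccc1` has not yet been measured. It differs from compound 2 through the change hydrogen in place of 2-(dimethylamino)ethyl on a saturated chain carbon bound to a nitrogen on an aromatic ring with hydrogen in place of 2-(dimethylamino)ethyl on a saturated chain carbon bound to a nitrogen on an aromatic ring, so that 3-(dimethylamino)propyl gives way to methyl. Because compound 1 with its methyl stands at 55000 nM in this assay a moderate rise is expected rather than a fall. The estimated step is a rise a 2.1-fold higher number from compound 2 to compound 3 (0.33 log units; beyond the scatter) in the number tolerated. The estimate for compound 3 is 30000 nM with an expected range (from 11000 nM to 80000 nM).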

Compound 3, half-maximal cytotoxic concentration: > 100000 nM
Compound 3 ended at the assay's limit; the forecaster's own chance of this, stated with the estimate: 20%; middle value at least 3.3-fold (0.52 log units) away from the limit.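

In this assay compound 3 gives > 100000 nM, which is a limit of the assay and not a number: the limit of > 100000 nM in this assay, at which 1 of the 3 values shown sits.

With the nitro group kept in place, 3-(dimethylamino)propyl giving way to methyl yields an at least 7.1-fold higher number from compound 2 to compound 3 (0.85 log units; beyond the scatter), so the low number of compound 2 goes with its side chain and not with the nitro group alone. Nitro in place of hydrogen on an aromatic carbon, read on its own, gives an at least 1.8-fold higher number from compound 1 to compound 3 (0.25 log units; that floor lies within the scatter), which shows no fall in the tolerated concentration but supports no claim of a rise.

From the compounds shown here alone, how far compound 3 lies past the limit stays open, and with it the true size of both steps. Also open, going by these compounds, is whether the chain or its end group matters more, as a shorter chain, a primary amine or a carboxylic acid at the chain end could show.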